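The source may report more compounds than this note shows. Statements on the series, on what has been measured and on what is new or still open speak of the compounds shown alone.

Measured in a physicochemical assay for lipophilicity, using the shake flask method, measured as octanol-water partition, at pH 7.4; a lower number here means a more polar compound, a higher number a more lipophilic compound:
- compound 1 `CC(=O)N[C@@H]1CCC[C@H](C(=O)Nc2cc(-c3cnn4c3CCC4)c(Cl)cn2)C1`: 2.9
- compound 2 `CC(=O)N[C@@H]1CCC[C@H](C(=O)Nc2cc(-c3cnn4c3CC(C)(C)C4)ccn2)C1`: 2.8
- compound 3 `CC(=O)N[C@@H]1CC[C@H](C(=O)Nc2cc(-c3cnn4c3CC(C)(C)C4)c(Cl)cn2)C1`: 3.5

Compound 3 stands highest of the three, and compound 1 and compound 2 both lie lower by more than the scatter. Compound 4 `CC1(C)Cc2c(-c3cc(NC(=O)[C@H]4C[C@@H](O)C4)ncc3Cl)cnn2C1` carries 3-hydroxycyclobutyl in place of 3-acetamidocyclopentyl on a carbonyl carbon. Among the compounds with values here, no measured pair differs in one place only, so the size of this step in this assay rests on the structural change alone. A modest fall, just beyond the scatter, is expected, with a number 0.40 log units lower from compound 3 to compound 4 (beyond the scatter) as the estimated step. The estimate for compound 4 is 3.1, with an expected range of 2.6 to 3.5.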

Compound 4, distribution coefficient: 3.2
Compound 4: the middle estimate sits 0.10 log units below what was measured, within the range that was stated.
By their numbers in this assay, from the lowest: compounds 2, 1, 4 and 3 (each within the scatter of the next, the first and the last beyond it).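

In this assay, within the data shown here, 3-hydroxycyclobutyl in place of 3-acetamidocyclopentyl on a carbonyl carbon gives a number 0.30 log units lower from compound 3 to compound 4 (within the scatter), the first step that can be read at a single place. The exchange takes the group from 9 heavy atoms to 5 with the hydrogen-bond donor and acceptor counts unchanged, so this large a cut in the group leaves the number within the scatter. Still open, as far as these compounds go, is whether an amine, a carboxylic acid or a longer chain at this place would give a step beyond the scatter, and how ring size and the hydroxyl each contribute. No measurement shown bears on the cause of this step.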